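This account rests on a few compounds, and the source may have more. Where it says the series, first, only, none or still open, it means among the compounds named here.

Among the compounds with values here, compound 1 `O=C(Nc1ccc(C(F)(F)F)cc1)c1ccc(OC(F)(F)F)cc1` is the only compound here with a full number in a functional assay on HEK293 cells for antagonist activity at transient receptor potential cation channel subfamily V member 1 (Homo sapiens), read by calcium flux; a higher number here means a weaker inhibitor, a lower number a stronger inhibitor; in this assay compound 1 gives 220 nM. Compound 2 `O=C(Nc1ccc(-c2ccccc2)cc1)c1ccc(OC(F)(F)F)cc1` gives only a limit in this assay, > 10000 nM. Within the data shown here, the one measured step, an at least 45-fold higher number from compound 1 to compound 2 (1.65 log units; beyond the scatter), alters the ring that carries the trifluoromethyl. Compound 3 `O=C(Nc1ccc(C(F)(F)F)cc1)c1ccc(I)cc1` alters the other ring of the shared core instead: iodo in place of trifluoromethoxy on an aromatic carbon. Among the measured compounds shown here, no measured step bears on this change, so no direction is expected, only a step within the usual scatter, a 1.4-fold higher number from compound 1 to compound 3 (0.13 log units; within the scatter). Compound 3 is therefore estimated at 300 nM in this assay, most likely between 100 nM and 1000 nM.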

Compound 3, half-maximal inhibitory concentration: > 10000 nM
Compound 3 ended at the assay's limit; the forecaster's own chance of this, stated with the estimate: 5%; middle value at least 33-fold (1.52 log units) away from the limit.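

In this assay, within the data shown here, putting iodo in place of trifluoromethoxy gives an at least 45-fold higher number from compound 1 to compound 3 (1.65 log units; beyond the scatter) and so shows that this position is sensitive too, not only the one holding the trifluoromethyl. Compound 3 gives > 10000 nM and this is only a limit of the assay. The step is therefore a floor rather than a true size, and it cannot be ranked against the step to compound 2: the limit of > 10000 nM in this assay, at which 2 of the 3 values shown sit.

The compounds shown leave open whether another group at this position, such as methoxy, methyl or chloro, would keep the activity of compound 1.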